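The compounds below may be only part of what the source reports. "The series", "measured", "known", "first", "only" and "open" are said of these compounds alone.

In a functional assay on RAW264.7 cells (Mus musculus) for inhibition, with stated times of 2 h and 24 h (a lower number here means a stronger inhibitor, a higher number a weaker inhibitor), compound 1 (`COc1ccc([C@@H]2c3c(OC)cc(OC)cc3C(SCc3ccccc3)[C@H]2c2cc(OC)cc(OC)c2)cc1`) gives > 200000 nM, which is a limit of the assay and not a number. Compound 2 (`COc1ccc([C@@H]2c3c(OC)cc(OC)cc3C(SCc3ccc(C)cc3)[C@H]2c2cc(OC)cc(OC)c2)cc1`) gives > 200000 nM, again a limit. Compound 3 (`COc1ccc(C(O)C2c3cc(OC)cc(OC)c3[C@@H](c3ccc(OC)cc3)[C@@H]2c2cc(OC)cc(OC)c2)cc1`) gives > 200000 nM, and this too is a limit, so compound 3 stands where the other two stand, with no number of its own. The evidence so far is the limit of > 200000 nM in this assay, at which 3 of the 3 values shown sit.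

Compound 4 (`COc1ccc([C@@H]2c3c(OC)cc(OC)cc3C(C(O)c3ccc(C)cc3)[C@H]2c2cc(OC)cc(OC)c2)cc1`) departs from compound 3 through one change, methyl in place of methoxy on an aromatic carbon, para to a large group, so that hydroxy(4-methoxyphenyl)methyl becomes hydroxy(4-methylphenyl)methyl.

Going by the values given here, three measured steps bear on this change. The closest in kind is a step that the two limits leave unreadable from compound 1 to compound 2, which also places a methyl on an aromatic carbon. The other two are a step that the two limits leave unreadable from compound 1 to compound 3 and a step that the two limits leave unreadable from compound 2 to compound 3, both of which arrive at the hydroxy(4-methoxyphenyl)methyl group. None of them gives a size to carry over, and no shift beyond the scatter is expected in this assay on this evidence. The expected outcome is a number no higher from compound 3 to compound 4 (the limit leaves the size open), with no direction favoured. The estimate for compound 4 is 200000 nM, within an expected range of 60000 nM to 400000 nM, and the assay is expected most probably to report only a limit.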

Compound 4, half-maximal inhibitory concentration: 26500 nM
Beside the measured number, compound 4's estimate is 7.5-fold (0.88 log units) above it, outside the stated range (below it).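

Going by these compounds alone, at this position, the replacement of methoxy by methyl, which turns 4-methoxyphenyl into 4-methylphenyl, is the first change in this assay whose effect can be read, and it gives an at least 7.5-fold lower number from compound 3 to compound 4 (0.87 log units; beyond the scatter). Hydroxy(4-methylphenyl)methyl in place of the sulfanyl groups gives an at least 7.5-fold lower number from compound 2 to compound 4 (0.87 log units; beyond the scatter) and also an at least 7.5-fold lower number from compound 1 to compound 4 (0.87 log units; beyond the scatter), whereas the earlier steps among the first three compounds cannot be read, so the one-atom-smaller methyl group on the aromatic carbon separates a measurable compound from one that stays at the limit. Compound 4 is the only compound of the four with a number and not a limit, and each of these three steps has a limit as its starting point, so its full size stays unknown: the limit of > 200000 nM in this assay, at which 3 of the 4 values shown sit.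

The compounds shown leave open whether methyl itself matters or whether the loss of methoxy is enough, a question that a hydrogen, a chlorine or an ethyl on the same aromatic carbon would address. They also leave open whether the hydroxy group contributes to the value of compound 4, which a carbonyl or a methylene at that carbon would test.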